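The source may report more compounds than this note shows. Statements on the series, on what has been measured and on what is new or still open speak of the compounds shown alone.

Measured compounds:
Compound 1, `N#CNC(=N)NCCCCCn1nc(-c2ccccc2)ccc1=O`: in a functional assay on the whole organism (stomach) with Rattus norvegicus as the target (on this read-out lower numbers stand for an effect already at smaller amounts and higher numbers for an effect only at larger amounts of compound), compound 1 gives > 100 mg/kg, which is a limit of the assay and not a number.
Compound 2, `CC/N=C(/NC#N)NCCCn1nc(-c2ccccc2)ccc1=O`: in this assay compound 2 gives 78.3 mg/kg.
Compound 3, `N/C(S)=N/CCCCn1nc(-c2ccccc2)ccc1=O`: in this assay compound 3 gives 36.3 mg/kg.

Compound 3 has the lowest of the two numbers; its nearest neighbour is compound 2, with a 2.2-fold lower number from compound 2 to compound 3 (0.33 log units; beyond the scatter). Compound 4, `CC/N=C(\S)NCCCn1nc(-c2ccccc2)ccc1=O`, differs from compound 3 by a group of 6 heavy atoms (3 carbon, 2 nitrogen, 1 sulfur; no ring) in place of a group of 5 heavy atoms (2 carbon, 2 nitrogen, 1 sulfur; no ring), on a saturated chain carbon, three bonds along the chain from an aromatic nitrogen. The closest measured parallel is the change from compound 1 to compound 2, where a similar carbon extension on the chain end gave an at least 1.2-fold lower number from compound 1 to compound 2 (0.10 log units; that floor lies within the scatter). A step of about that size, or none beyond the scatter, is therefore expected in this assay. Compound 4 is estimated at 40 mg/kg, within 18 mg/kg to 90 mg/kg, meaning an expected 1.1-fold higher number from compound 3 to compound 4 (0.04 log units; within the scatter).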

Compound 4, dose for half-maximal effect: > 100 mg/kg
Compound 4 ended at the assay's limit; the forecaster's own chance of this, stated with the estimate: 10%; at least 2.5-fold (0.39 log units) between middle value and limit.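

In this assay, the group of 6 heavy atoms in place of the group of 5 heavy atoms, on a saturated chain carbon, gives an at least 2.7-fold higher number from compound 3 to compound 4 (0.44 log units; beyond the scatter), so a small change at this position can cost readable effect. On an amine nitrogen, the group of 5 heavy atoms in place of the group of 7 heavy atoms gives an at least 1.2-fold higher number from compound 2 to compound 4 (0.10 log units; that floor lies within the scatter), so no difference can be claimed there. The values of compound 1 and compound 4 are both limits, so the step between them cannot be read: the limit of > 100 mg/kg in this assay, at which 2 of the 4 values shown sit.

Going by these compounds, what an amine or a longer chain at this position would give remains open. So does whether any group here would take the number below that of compound 3.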